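Methoxy in Place of Hydroxymethyl in a P2X7 Antagonist Series

The compounds below may be only part of what the source reports. "The series", "measured", "known", "first", "only" and "open" are said of these compounds alone.

Compound 1 `Cc1ccc(-c2ccc(Cl)c(C(=O)NCC3(O)CCCCCC3)c2)nn1` and compound 2 `O=C(NCC1(O)CCCCCC1)c1cc(-c2ccc(CO)cn2)ccc1Cl` share a core and differ only in one aromatic group. In a functional assay on HEK293 cells for antagonist activity at P2X purinoceptor 7 (Homo sapiens) (a lower number here means a stronger inhibitor, a higher number a weaker inhibitor), compound 1 gives 18 nM, and compound 2 gives 17 nM; the step of a 1.1-fold lower number from compound 1 to compound 2 (0.02 log units; within the scatter) lies within the scatter, so compound 2 merely shows the lower of the two numbers. Compound 3 `COc1ccc(-c2ccc(Cl)c(C(=O)NCC3(O)CCCCCC3)c2)nc1` carries methoxy in place of hydroxymethyl on an aromatic carbon. Among the measured compounds shown here, no measured step tests this exact exchange; the only step available, from compound 1 to compound 2, swapped a whole ring group without moving the number beyond the scatter. Compound 3 is therefore expected to stay close, a 1.2-fold higher number from compound 2 to compound 3 (0.07 log units; within the scatter), at an estimated 20 nM within a range from 8 nM to 55 nM.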

Compound 3, half-maximal inhibitory concentration: 213 nM
Beside the measured number, compound 3's estimate is 11-fold (1.03 log units) below it; measured number outside the range, above it.
By their numbers in this assay, from the lowest: compounds 2 and 1 (each within the scatter of the next); then compound 3.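

In this assay, this position proves sensitive to a change that keeps the same atoms: methoxy in place of hydroxymethyl costs clearly (a 13-fold higher number from compound 2 to compound 3 (1.10 log units; beyond the scatter)). The earlier exchange of whole ring groups left the number within the scatter, yet 5-methoxypyridin-2-yl also falls well short of 6-methylpyridazin-3-yl (a 12-fold higher number from compound 1 to compound 3 (1.07 log units; beyond the scatter)). Hydroxymethyl carries a hydrogen-bond donor and methoxy none, but no supporting measurement is available to explain the loss. On these data alone, whether that donor matters remains open. An aminomethyl or a carboxylic acid at this position, or ethoxy in place of methoxy, would help to test it.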